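The source may hold more compounds than are shown below. What is called first, only, known or untested is meant among the compounds shown, and "the series" means these compounds.

Working notes on the series, in an ADME assay on microsomes from liver (Rattus norvegicus) for metabolic stability; on this read-out lower numbers stand for slow clearance and higher numbers for fast clearance: compound 1 (`Cc1ccc(NC(=O)c2cc(Oc3ccc(S(C)(=O)=O)cc3)cc(OC(C)C)c2)nc1`) gives 97 mL/min/kg and compound 2 (`CC(C)Oc1cc(Oc2ccc(S(C)(=O)=O)cc2)cc(-c2nccc(=O)[nH]2)c1`) gives 105 mL/min/kg, so the two stand level within the scatter. Compound 3 (`CNS(=O)(=O)c1ccc(Oc2cc(OC(C)C)cc(-c3nccc(=O)[nH]3)c2)cc1`) has methylamino in place of methyl on a sulfonyl sulfur. Within the data shown here, the only measured step, a 1.1-fold higher number from compound 1 to compound 2 (0.03 log units; within the scatter), lies within the scatter but concerns a different place, so it bears only indirectly. Among the measured compounds shown here, no measured step covers the sulfonyl sulfur. A small downward move, within the scatter, is expected: a 1.2-fold lower number from compound 2 to compound 3 (0.09 log units; within the scatter). The estimate for compound 3 is 85 mL/min/kg, with an expected range of 45 mL/min/kg to 140 mL/min/kg.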

Compound 3, clearance: 112 mL/min/kg
Compound 3: middle estimate off by 1.3-fold (0.12 log units), on the low side; measured number inside the range.
By their numbers in this assay, from the lowest: compounds 1, 2 and 3 (each within the scatter of the next).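

In this assay, methylamino in place of methyl on a sulfonyl sulfur leaves the two compounds level within the scatter (a 1.1-fold higher number from compound 2 to compound 3 (0.03 log units; within the scatter)). Among these compounds, this gives the first measured step at this position, and the hydrogen-bond donor counted for methylamino brings no readable difference on this read-out. Nothing available accounts for this result.

Still open, as far as these compounds go, is whether a plain amino, dimethylamino or a longer chain on the nitrogen of the methylsulfamoyl group would also stand level. The same question holds for a carboxylic acid in place of the sulfonyl group.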